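Methyl for Methoxy on a Glutamate Receptor Modulator Scaffold

The compounds below may be only part of what the source reports. "The series", "measured", "known", "first", "only" and "open" are said of these compounds alone.

Compound 1 `COc1cc(C(=O)O)ccc1OCCCCOc1ccc(C(=O)C(C)C)c(O)c1C` stands lowest of the two measured compounds in an assay on HEK293 cells for positive allosteric modulation of metabotropic glutamate receptor 2 (Rattus norvegicus), read by thallium flux, with a stated time of 2.5 min (on this read-out lower numbers stand for smaller maximal responses and higher numbers for larger maximal responses), where compound 1 gives 73.1%. Going by the values given here, compound 2 `COc1cc(C(=O)O)ccc1OCCCCOc1ccc(C(=O)CC(C)C)c(O)c1C` gives 85.7% in this assay, and the only measured step, a number 12.6 percentage points higher from compound 1 to compound 2 (beyond the scatter), concerns the group on a carbonyl carbon. Compound 3 `Cc1cc(C(=O)O)ccc1OCCCCOc1ccc(C(=O)C(C)C)c(O)c1C` differs from compound 1 elsewhere in the shared core: methyl in place of methoxy on an aromatic carbon. Among the compounds with values here, no measured step touches this part of the molecule, so the modest gain seen on the carbonyl carbon gives no guidance here, and no step beyond the scatter is expected in this assay in either direction. Compound 3 is therefore estimated to give 73% in this assay, within a range of 55% to 90%. The expected step from compound 1 is a number 0.1 percentage points lower from compound 1 to compound 3 (within the scatter).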

Compound 3, largest response reached (reported as percent of maximum), in percent of the reference or control that the assay uses: 76.9%
Estimate against measurement, compound 3: 3.9 percentage points below; the measured number falls inside the stated range.
By their numbers in this assay, from the lowest: compounds 1, 3 and 2 (each within the scatter of the next, the first and the last beyond it).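

In this assay, replacing the methoxy on the aromatic carbon, ortho to a large group and meta to a carboxy group, with methyl gives a number 3.8 percentage points higher from compound 1 to compound 3 (within the scatter) and is the first change shown in this part of the shared core. The oxygen and its one hydrogen-bond acceptor can thus leave this position while compound 1 and compound 3 remain within the scatter of each other, unlike the earlier step on the carbonyl carbon, which lay beyond it. No available evidence bears on the reason for this result.

On these data alone, it remains open what other groups on this aromatic carbon, such as a chlorine atom, an ethoxy group or an amine, would do to the maximal response. As far as these compounds go, it is also open whether the isobutyl group on the carbonyl carbon would give a similar step in a molecule carrying methyl in place of methoxy.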